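Aryl exchange on the acid series: compound 1 to compound 4

The compounds below may be only part of what the source reports. "The series", "measured", "known", "first", "only" and "open" are said of these compounds alone.

Compound 1 `O=C(O)CCCC/C=C(\c1cccnc1)c1cccc(Br)c1` is measured in an assay (Equus caballus) for inhibition of Thromboxane-A synthase (Homo sapiens), using microsomes (on this read-out higher numbers stand for weaker inhibition and lower numbers for stronger inhibition), at 180 nM. Compound 2 `COC(=O)CCCC/C=C(\c1ccccc1)c1cccnc1` gives 100 nM in this assay, a number within the scatter of compound 1, so no order between the two is read. Compound 3 `O=C(O)CCCCCCCCC/C=C(/c1ccccc1)c1cccnc1` gives 520 nM in this assay, weaker inhibition than compound 1 by a margin beyond the scatter; compound 1 thus holds the second highest of the three numbers. Compound 4 `O=C(O)CCCC/C=C(/c1ccc(F)cc1)c1cccnc1` differs from compound 1 in one place: 4-fluorophenyl in place of 3-bromophenyl on a double-bonded chain carbon bound to an aromatic carbon and a double-bonded chain carbon. For the measured compounds named here, no step between measured compounds covers such an exchange of one aryl group for another. The step is expected to be small, a 1.2-fold lower number from compound 1 to compound 4 (0.08 log units; within the scatter) being the estimated size, in no direction beyond the scatter. Compound 4 is therefore expected at 150 nM, in the range 60 nM to 400 nM.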

Compound 4, half-maximal inhibitory concentration: 83 nM
Estimate against measurement, compound 4: 1.8-fold (0.26 log units) above, within the range that was stated.
By their numbers in this assay, from the lowest: compounds 4, 2 and 1 (each within the scatter of the next, the first and the last beyond it); then compound 3.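

In this assay, for the compounds shown here, the aryl group on a double-bonded chain carbon bound to an aromatic carbon and a double-bonded chain carbon proves sensitive to exchange: 4-fluorophenyl in place of 3-bromophenyl gives a 2.2-fold lower number from compound 1 to compound 4 (0.34 log units; beyond the scatter) as the first readable step. The step is modest. No measurement at hand gives a reason for it.

This single step does not separate the change of halogen from the change of its place on the ring. As far as these compounds go, how 4-bromophenyl, 3-fluorophenyl or a ring bearing a nitrile would compare remains open.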